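This account rests on a few compounds, and the source may have more. Where it says the series, first, only, none or still open, it means among the compounds named here.

The series shares the core seen in compound 1 `O=C(NCc1cccc(N2CCc3ccccc32)c1)C1CC1`, compound 2 `c1cc(CNCC2CC2)cc(N2CCc3ccccc32)c1` and compound 3 `CC(N)c1cccc(N2CCc3ccccc32)c1`. In a functional assay on the whole organism for inhibition, with Mus musculus as the target, in the writhing test, at a dose of 10 mg/kg by the subcutaneous route (a lower number here means less inhibition, a higher number more inhibition at the dose given (going by the name of the read-out)), compound 1 gives 69%, compound 2 gives 69% and compound 3 gives 69%. The steps among them: no change at the digits printed from compound 1 to compound 2 (within the scatter); no change at the digits printed from compound 1 to compound 3 (within the scatter); no change at the digits printed from compound 2 to compound 3 (within the scatter). Compound 3 thus stands level with compounds 1 and 2 at the digits shown, compound 1 being nearest and compound 2 furthest, both within the scatter.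

Compound 4 `NC(c1ccccc1)c1cccc(N2CCc3ccccc32)c1` differs from compound 3 as follows: phenyl in place of methyl on a saturated chain carbon bound to an amine nitrogen and an aromatic carbon. Among the compounds with values here, none of the measured steps exchanges one group for another on the saturated chain carbon bound to the amine nitrogen; the measured steps alter the substituent on the amine or replace the whole side chain, and each left this assay unchanged within the scatter. Within the data shown here, no step therefore bears directly on the change from compound 3 to compound 4; the series shows only that three different side chains on the shared core all sit at one level. On that ground the expected step of a number 4 percentage points lower from compound 3 to compound 4 (within the scatter) is none beyond the scatter, with some allowance for the larger group entering. Compound 4 is estimated at 65% in this assay, with a range from 45% to 82%.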

Compound 4, a percentage reported as inhibition, in the whole organism at one dose (the size of the read-out at that dose, not a potency): 69%
For compound 4 the middle estimate is 4 percentage points below the measured one, and the stated range covers the measured number.
By their numbers in this assay, from the lowest: compounds 1, 2, 3 and 4 (each within the scatter of the next).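

Phenyl in place of methyl on a saturated chain carbon bound to an amine nitrogen and an aromatic carbon, the only exchange shown at this carbon itself, gives no change at the digits printed from compound 3 to compound 4 (within the scatter) in this assay. The earlier steps shown here altered the substituent on the amine or replaced the whole side chain; this one shows that a single group on the carbon can go from 1 heavy atom to 6 heavy atoms, with one six-membered aromatic ring of carbon only, and the read-out still stands level with the other three compounds. The data at hand offer no measurement that accounts for this level result.

All four compounds sit at one level at a single dose, so this read-out gives the size of the effect at that dose and no potency order among them. Still open, going by these compounds, is whether this carbon keeps that level when it carries a carboxylic acid, a longer chain such as butyl, or a phenyl ring bearing a fluorine atom, and whether a lower dose would separate methyl from phenyl.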